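The source may report more compounds than this note shows. Statements on the series, on what has been measured and on what is new or still open speak of the compounds shown alone.

Working notes on the series.

Compound 1 `COc1ccccc1/C=c1/[nH]c(=O)/c(=C\c2ccccc2OC)[nH]c1=O` carries two 2-methoxyphenyl groups and no substituent on the ring nitrogens; in a functional assay on HL-60 cells (Homo sapiens) for cytotoxicity, read by CCK-8 assay, with a stated time of 72 h (a higher number here means a weaker inhibitor, a lower number a stronger inhibitor), compound 1 is reported as "not active" (no number reported), with no number given. Compound 2 `COc1ccccc1/C=c1\c(=O)[nH]/c(=C/c2ccccc2Cl)c(=O)n1C` gives 200 nM in this assay. Compound 3 `C=CCn1c(=O)/c(=C\c2ccccc2OC)[nH]c(=O)/c1=C\c1ccccc1OC` gives 15700 nM in this assay, the higher of the two numbers available; compound 2 sits well below it, a gap that lies beyond the scatter. Within the data shown here, compound 2 and compound 3 differ in more than one place, so no single step between them can be read from their two values alone.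

Compound 4 `C=CCn1c(=O)/c(=C\c2cc(Br)ccc2F)[nH]c(=O)/c1=C\c1ccccc1OC` has not yet been measured. Its difference from compound 3 is 5-bromo-2-fluorophenyl in place of 2-methoxyphenyl on a double-bonded chain carbon bound to an aromatic carbon. Among the measured compounds shown here, the only measured compound bearing a halogen-substituted phenyl, compound 2, is the one with the low number, while both compounds with two 2-methoxyphenyl groups, compound 1 and compound 3, sit at the weak end; this rests on a single comparison and compound 2 also differs in its nitrogen substituent. On that basis a step from compound 3 to compound 4 toward a lower number, of moderate size and likely beyond the scatter, is expected: a 3.9-fold lower number from compound 3 to compound 4 (0.59 log units; beyond the scatter). For compound 4 in this assay the estimate is 4000 nM, with a range from 800 nM to 20000 nM.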

Compound 4, half-maximal inhibitory concentration: 17400 nM
For compound 4 the middle estimate is 4.4-fold (0.64 log units) below the measured one, and the stated range covers the measured number.
By their numbers in this assay, from the lowest: compound 2; then compounds 3 and 4 (each within the scatter of the next).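

Among these compounds, the swap of 2-methoxyphenyl for 5-bromo-2-fluorophenyl on a double-bonded chain carbon bound to an aromatic carbon is the first single-place step, and in this assay it gives a 1.1-fold higher number from compound 3 to compound 4 (0.04 log units; within the scatter). With the rest of the structure held constant, this position therefore accepts the two rings without a separation beyond the scatter, and the halogen-bearing ring alone does not bring compound 4 apart from compound 3, despite the two rings sharing no substituent. No measured evidence on the compounds shown accounts for this result.

The compounds shown leave open whether the number of compound 2, 200 nM, is tied to its substituent on the ring nitrogen, to its own halogen-bearing phenyl, or to the two together, since compound 2 differs from compound 3 in more than one place. They also leave open whether a phenyl carrying an amine or a carboxylic acid at this same place would give a number outside the scatter of compound 3.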